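Swapping the Five-Membered Ring on a Urea Tail

The source may report more compounds than this note shows. Statements on the series, on what has been measured and on what is new or still open speak of the compounds shown alone.

Two urea compounds built on a shared core have been measured in an assay on isolated protein for inhibition of proto-oncogene tyrosine-protein kinase receptor Ret variant V804M (Homo sapiens), read by 33P incorporation, with stated times of 15 min and 40 min; on this read-out higher numbers stand for weaker inhibition and lower numbers for stronger inhibition. Compound 1 `O=C(Nc1ccc(Nc2ncnc3c2OCCN3)cc1)Nc1ccc(C(F)(F)F)cc1` carries a 4-(trifluoromethyl)phenyl group on one urea nitrogen and gives 276 nM. Compound 2 `CC(C)(C)c1cc(NC(=O)Nc2ccc(Nc3ncnc4c3OCCN4)cc2)no1` replaces that group with 5-(tert-butyl)-1,2-oxazol-3-yl and gives 34 nM, the lowest of the two numbers; the step of an 8.1-fold lower number from compound 1 to compound 2 (0.91 log units; beyond the scatter) shows this change improved inhibition.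

Compound 3 `CC(C)(C)c1csc(NC(=O)Nc2ccc(Nc3ncnc4c3OCCN4)cc2)n1` keeps the tert-butyl-bearing five-membered ring but changes the ring itself: 4-(tert-butyl)-1,3-thiazol-2-yl in place of 5-(tert-butyl)-1,2-oxazol-3-yl on an amide-type nitrogen. Going by the values given here, no measured step covers this particular exchange, so only the step from compound 1 to compound 2 offers guidance, and it concerns a different change. Since both rings carry the same tert-butyl group and the same count of heavy atoms and acceptors, a small step is expected in this assay , in either direction or none beyond the scatter, as a 1.0-fold higher number from compound 2 to compound 3 (0.01 log units; within the scatter) indicates. Compound 3 is therefore estimated at 35 nM, within a range from 10 nM to 120 nM.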

Compound 3, half-maximal inhibitory concentration: 5170 nM
The estimate for compound 3 lay 150-fold (2.17 log units) below the measured number; the whole stated range lies below it.
By their numbers in this assay, from the lowest: compound 2; then compound 1; then compound 3.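

At this amide-type nitrogen, the make-up of the five-membered ring turns out to matter a great deal: in this assay there is a 150-fold higher number from compound 2 to compound 3 (2.18 log units; beyond the scatter), even though 5-(tert-butyl)-1,2-oxazol-3-yl and 4-(tert-butyl)-1,3-thiazol-2-yl have the same counts of heavy atoms, hydrogen-bond donors and hydrogen-bond acceptors. Nor does a five-membered ring bearing tert-butyl always beat 4-(trifluoromethyl)phenyl, as a 19-fold higher number from compound 1 to compound 3 (1.27 log units; beyond the scatter) runs opposite to the gain seen with compound 2, so the earlier improvement belongs to the 1,2-oxazol-3-yl group and does not extend to every ring of this kind. No measurement is available that would explain this large difference between two such similar groups.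

The exchange puts sulfur in place of oxygen and also rearranges the ring atoms and the tert-butyl group, so this single step cannot show which of these changes carries the loss. On these data alone, it also remains open whether the 1,2-oxazol-3-yl ring keeps its low number when tert-butyl is replaced by a smaller group such as cyclopropyl or methyl.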